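Trifluoromethyl removal on the amino core: clearance note

A few compounds are considered here, and "the series" means these few. Any claim that something is new, unique, unknown or untested is made for them only; others in the source may bear on it.

Compound 1 `O=c1ccc(-c2ccc3cn[nH]c3c2)cn1Cc1cccc(C(F)(F)F)c1` and compound 2 `O=c1ccc(-c2ccc3cn[nH]c3c2)cn1Cc1ccccc1` share one core; compound 3 `Nc1n[nH]c2cc(-c3ccc(=O)n(Cc4cccc(C(F)(F)F)c4)c3)ccc12` and compound 4 `Nc1n[nH]c2cc(-c3ccc(=O)n(Cc4ccccc4)c3)ccc12` share another, and the two cores differ by amino in place of hydrogen on an aromatic carbon. In an ADME assay on microsomes (Mus musculus) for metabolic stability, read by LC-MS, using NADPH, with a stated time of 1 h, tested at 1 uM (a lower number here means slower removal, a higher number faster removal of the compound), compound 1 gives 63 mL.min-1.g-1, while compound 2 gives 157 mL.min-1.g-1. Compound 3 reaches only < 10 mL.min-1.g-1 in this assay, which is a limit of the assay and not a number. The change from compound 1 to compound 2 is hydrogen in place of trifluoromethyl on an aromatic carbon, and it made a 2.5-fold higher number from compound 1 to compound 2 (0.40 log units; beyond the scatter). The change from compound 3 to compound 4 is hydrogen in place of trifluoromethyl on an aromatic carbon, the same change carried onto the other core, at the same place. The step between the cores was an at least 6.3-fold lower number from compound 1 to compound 3 (0.79 log units; beyond the scatter); its full size is not known because of the limit of < 10 mL.min-1.g-1 in this assay, at which 1 of the 3 values shown sits. For compound 4 the step in this assay is expected to be an at least 1.4-fold higher number from compound 3 to compound 4 (0.14 log units; that floor lies within the scatter). This expectation rests on a 2.5-fold higher number from compound 1 to compound 2 (0.40 log units; beyond the scatter), applied from a starting point that is itself a limit, so compound 4 may again be reported only as a limit. The estimate for compound 4 in this assay is 14 mL.min-1.g-1, with a range from 5 mL.min-1.g-1 to 35 mL.min-1.g-1.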

Compound 4, intrinsic clearance in microsomes: < 10 mL.min-1.g-1
Compound 4: no number, only a limit; the forecaster's own chance of this, stated with the estimate: 35%; middle value at least 1.4-fold (0.14 log units) away from the limit.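

In this assay compound 4 gives < 10 mL.min-1.g-1, which is a limit of the assay and not a number, and the step from compound 3 to compound 4 cannot be read. Amino in place of hydrogen, now seen without the trifluoromethyl, gives an at least 15-fold lower number from compound 2 to compound 4 (1.19 log units; beyond the scatter), the same direction as with the trifluoromethyl present, and the two readings stand as follows: the same change on two cores in this assay, an at least 6.3-fold lower number (0.79 log units; beyond the scatter) from compound 1 to compound 3 and an at least 15-fold lower number (1.19 log units; beyond the scatter) from compound 2 to compound 4; the limit leaves it open whether they differ The direction of the amino change therefore carries across this pair of cores, but neither its full size nor any carrying over of a 2.5-fold higher number from compound 1 to compound 2 (0.40 log units; beyond the scatter) onto the amino core is shown, and the reach of the data ends here: the limit of < 10 mL.min-1.g-1 in this assay, at which 2 of the 4 values shown sit.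

Still open, from the compounds shown here alone, is whether hydrogen in place of trifluoromethyl changes the clearance at all on the amino core, where neither compound yields a number. Also open, going by these compounds, is how a methoxy or a chlorine in place of the trifluoromethyl, or a methylamine in place of the amino, would read in this assay.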